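Opening the Aminopiperidine Ring: Expected Effect on Clearance

The source may report more compounds than this note shows. Statements on the series, on what has been measured and on what is new or still open speak of the compounds shown alone.

Measured so far in an ADME assay on cells (Hepatocyte, Rattus norvegicus) for metabolic stability; a lower number here means slower removal, a higher number faster removal of the compound:
Compound 1 `CC(=O)Nc1cc(Nc2cc(NC3CC3)n3ncc(C#N)c3n2)ccc1N1CCC[C@@H](N)C1` gives < 1 uL/min, which is a limit of the assay rather than a number.
Compound 2 `CCN(CC)CCN(C)c1ccc(Nc2cc(NC3CC3)n3ncc(C#N)c3n2)cc1NC(C)=O` gives 27 uL/min.
Compound 3 `CC(=O)Nc1cc(Nc2cc(NC3CC3)n3ncc(C#N)c3n2)ccc1NCCCO` gives 17 uL/min.

Compound 1 therefore stands at the bottom edge of what this assay can report: the limit of < 1 uL/min in this assay, at which 1 of the 3 values shown sits. Compound 2 and compound 3 both give numbers well inside the measurable range.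

Compound 4 `CCN(CCN)c1ccc(Nc2cc(NC3CC3)n3ncc(C#N)c3n2)cc1NC(C)=O` has not yet been measured. Its structure differs from compound 1 in one place: a group of 6 heavy atoms (4 carbon, 2 nitrogen; no ring) in place of a group of 7 heavy atoms (5 carbon, 2 nitrogen; one six-membered non-aromatic ring with 1 hetero atom), on an aromatic carbon.

Among the compounds with values here, two measured steps bear on this change, and both start from compound 1. One is an at least 27-fold higher number from compound 1 to compound 2 (1.43 log units; beyond the scatter). The other is an at least 17-fold higher number from compound 1 to compound 3 (1.23 log units; beyond the scatter). In each of these the 3-aminopiperidin-1-yl group is exchanged for a group without a ring, which is also what happens in compound 4. The two ring-free compounds themselves differ little from each other: a 1.6-fold lower number from compound 2 to compound 3 (0.20 log units; within the scatter).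

On this basis compound 4 is expected to show a large rise in this assay relative to compound 1, roughly an at least 15-fold higher number from compound 1 to compound 4 (1.17 log units; beyond the scatter). The estimated value for compound 4 is 15 uL/min, with an expected range from 4 uL/min to 50 uL/min.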

Compound 4, intrinsic clearance in a liver preparation (reported as CLH), per the amount of preparation that the assay uses in the Hepatocyte assay: 2 uL/min
The estimate for compound 4 lay 7.5-fold (0.88 log units) above the measured number; the whole stated range lies above it.
By their numbers in the Hepatocyte assay, from the lowest: compound 4; then compounds 3 and 2 (each within the scatter of the next). At a limit, below all of these: compound 1.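

Compound 4 shows that having no ring does not by itself bring a high number in the Hepatocyte assay, since the three ring-free chains now differ widely: the step from the ring gives only an at least 2.0-fold higher number from compound 1 to compound 4 (0.30 log units; that floor lies within the scatter), whereas the chain changes give an 8.5-fold lower number from compound 3 to compound 4 (0.93 log units; beyond the scatter) and a 14-fold lower number from compound 2 to compound 4 (1.13 log units; beyond the scatter). In a physicochemical assay for solubility, read by LC-MS, in phosphate buffer, with a stated time of 24 h, at pH 7.4 (a lower number here means a less soluble compound, a higher number a more soluble compound), compound 1 gives > 1000000 nM, which is a limit of the assay. In the physicochemical assay compound 4 gives > 1000000 nM, which is also a limit of the assay.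

The step between these two solubility results cannot be read, because both compounds sit at the same limit: the limit of > 1000000 nM in the physicochemical assay, at which 2 of the 2 values shown sit. The compounds shown also leave open which part of the chain in compound 4 goes with its low number in the Hepatocyte assay, a question that a matching chain ending in a hydroxyl or a dimethylamino group could help to settle.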